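This account rests on a few compounds, and the source may have more. Where it says the series, first, only, none or still open, it means among the compounds named here.

Working notes on the series. Compound 1 `Nc1cccc2c1nc(-c1c(F)cccc1F)n2Cc1c(F)cccc1F` gives 26.3 uM in a toxicity assay on CCRF-CEM cells (Homo sapiens) for cytotoxicity; on this read-out higher numbers stand for lower toxicity in this test and lower numbers for higher toxicity in this test. Compound 2 `CC(=O)Nc1cccc2c1nc(-c1c(F)cccc1F)n2Cc1c(F)cccc1F` differs by acetyl in place of hydrogen on a nitrogen on an aromatic ring, and in this assay compound 2 gives 39.3 uM, a step of a 1.5-fold higher number from compound 1 to compound 2 (0.17 log units; within the scatter). Compound 3 `NCc1cccc2c1nc(-c1c(F)cccc1F)n2Cc1c(F)cccc1F` carries a different core, the difference being (aminomethyl in place of amino on an aromatic carbon); in this assay compound 3 gives 49.3 uM, with a 1.9-fold higher number from compound 1 to compound 3 (0.27 log units; within the scatter) and a 1.3-fold higher number from compound 2 to compound 3 (0.10 log units; within the scatter), so all three numbers sit within the scatter of one another.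

Compound 4 `CC(=O)NCc1cccc2c1nc(-c1c(F)cccc1F)n2Cc1c(F)cccc1F` is not yet measured. It differs from compound 3 by acetyl in place of hydrogen on an amine nitrogen. This is the same kind of change as from compound 1 to compound 2, but the place differs: there the acetyl enters on a nitrogen on an aromatic ring whose other neighbour is aromatic carbon, here on an amine nitrogen whose other neighbour is a saturated chain carbon. The expected step from compound 3 to compound 4 is a 1.2-fold higher number from compound 3 to compound 4 (0.09 log units; within the scatter), resting on the earlier step of a 1.5-fold higher number from compound 1 to compound 2 (0.17 log units; within the scatter), which stayed within the scatter. Compound 4 is therefore estimated at 60 uM, between 30 uM and 120 uM.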

Compound 4, half-maximal toxic concentration: 20.8 uM
Compound 4: the middle estimate sits 2.9-fold (0.46 log units) above what was measured; the measured number lies below the stated range.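

In this assay, acetyl in place of hydrogen does not carry over unchanged from the core of compound 1 to the core of compound 3; on the amine nitrogen whose other neighbour is a saturated chain carbon, the change gives a 2.4-fold lower number from compound 3 to compound 4 (0.37 log units; beyond the scatter), and the two steps differ: the same change on two cores in this assay, a 1.5-fold higher number (0.17 log units; within the scatter) from compound 1 to compound 2 and a 2.4-fold lower number (0.37 log units; beyond the scatter) from compound 3 to compound 4, 3.5-fold (0.55 log units) apart, beyond the scatter of two such steps

The other two new steps, a 1.9-fold lower number from compound 2 to compound 4 (0.28 log units; within the scatter) and a 1.3-fold lower number from compound 1 to compound 4 (0.10 log units; within the scatter), both stay within the scatter, so compound 4 is not separated from compound 1 or compound 2 on this read-out. The comparison rests on a single pair per core and a modest step, so it shows that the earlier step was a poor guide here, but it does not show why the two differ or whether the difference holds for other changes.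

From the compounds shown here alone, it remains open whether a propionyl or methyl group on the same nitrogen would follow the step seen on one core or the other. The same question applies to a longer chain in place of aminomethyl, such as aminoethyl.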